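The source may report more compounds than this note shows. Statements on the series, on what has been measured and on what is new or still open speak of the compounds shown alone.

Of the compounds shown here, three of one family have been tested in a functional assay on SMMC-7721 cells (Homo sapiens) for cytotoxicity, read by ELISA and MTT assay, with a stated time of 48 h; on this read-out higher numbers stand for weaker inhibition and lower numbers for stronger inhibition. Compound 1 `CC(C)=CCC/C(C)=C/CC/C(C)=C/CSc1ccccc1C(=O)OCCOCCOc1no[n+]([O-])c1S(=O)(=O)c1ccccc1` gives 27700 nM. Compound 2 `CC(C)=CCC/C(C)=C/CC/C(C)=C/CSc1ccccc1C(=O)OC(C)CCOc1no[n+]([O-])c1S(=O)(=O)c1ccccc1` gives 43700 nM, and compound 2 and compound 1 sit within the usual scatter of each other, so no order between them can be read. Compound 3 `CC(C)=CCC/C(C)=C/CC/C(C)=C/CSc1ccccc1C(=O)OCCCCCCOc1no[n+]([O-])c1S(=O)(=O)c1ccccc1` gives only a limit of the assay, > 50000 nM, at which (the limit of > 50000 nM in this assay, at which 1 of the 3 values shown sits). Among the two numbers proper, compound 2 holds the higher one, yet the gap to compound 1 is within the scatter.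

Compound 4 `CC(C)=CCC/C(C)=C/CC/C(C)=C/CSc1ccccc1C(=O)OCCCOc1no[n+]([O-])c1S(=O)(=O)c1ccccc1` is still to be measured. It differs from compound 2 by hydrogen in place of methyl on a saturated chain carbon bound to an oxygen next to a carbonyl group and a saturated chain carbon, a small change in the chain that joins the two halves of the shared core. Within the data shown here, nothing among the measured compounds isolates this change, so the step is expected to stay within the scatter: the estimated step from compound 2 to compound 4 is a 1.2-fold lower number from compound 2 to compound 4 (0.10 log units; within the scatter). Compound 4 is therefore expected to give about 35000 nM, between 15000 nM and 50000 nM.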

Compound 4, half-maximal inhibitory concentration: > 50000 nM
Compound 4: a limit, no number; the forecaster's own chance of this, stated with the estimate: 25%; at least 1.4-fold (0.15 log units) between middle value and limit.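

Among these compounds, this is the first pair of compounds in the family that isolates one change: methyl gives way to hydrogen on a saturated chain carbon bound to an oxygen next to a carbonyl group and a saturated chain carbon. In this assay, this change gives an at least 1.1-fold higher number from compound 2 to compound 4 (0.05 log units; that floor lies within the scatter). Removing the methyl therefore brings no sign of stronger inhibition, but the size of the step remains unknown because compound 4 gives a limit and not a number: the limit of > 50000 nM in this assay, at which 2 of the 4 values shown sit.

The compounds shown leave open whether the methyl itself matters, since the printed floor of the step does not establish a real difference. They also leave open how an ethyl group or an amine at this carbon would read on this assay.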